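Amide chain variation on a shared core

This account rests on a few compounds, and the source may have more. Where it says the series, first, only, none or still open, it means among the compounds named here.

Compound 3 `O=C(NCCCO)c1cc2ccccc2oc1=O` gives the lowest of the three numbers in an assay on HeLa cells for displacement of a labelled ligand from adenosine receptor A3 (Homo sapiens), read by scintillation counting, with a stated time of 180 min, tested at 10 uM (on this read-out lower numbers stand for less inhibition and higher numbers for more inhibition at the one concentration tested (going by the name of the read-out)), at 6%. The nearest value belongs to compound 1 `COc1cccc2cc(C(=O)NCC(=O)O)c(=O)oc12`, which gives 15%; the two lie within the scatter of each other. Compound 2 `O=C(NC1CCCC1)c1cc2ccccc2oc1=O` gives 20% and stands furthest off, the shift being a number 14 percentage points lower from compound 2 to compound 3 (beyond the scatter).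

Compound 4 `O=C(O)CNC(=O)c1cc2ccccc2oc1=O` differs from compound 3 by carboxy in place of 2-hydroxyethyl on a saturated chain carbon bound to an amide-type nitrogen. Among the compounds with values here, the only measured step on the amide-type nitrogen is the modest fall from the cyclopentyl to the 3-hydroxypropyl amide, and it exchanges a ring for a chain rather than one chain end for another, so it bears on the present change only loosely. Compound 1 carries the same carboxymethyl amide as compound 4 on a differently substituted core, and its number in this assay does not separate from compound 3 beyond the scatter. No shift beyond the scatter is therefore expected in this assay, and the expected step is a number 6 percentage points higher from compound 3 to compound 4 (within the scatter). Compound 4 is estimated at 12%, with a range from 2% to 25%.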

Compound 4, a percentage reported as inhibition, at one concentration (the size of the read-out at that concentration, not a potency): 0%
The estimate for compound 4 lay 12 percentage points above the measured number, outside the stated range (below it).
By their numbers in this assay, from the lowest: compounds 4, 3, 1 and 2 (each within the scatter of the next, the first and the last beyond it).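

In this assay, carboxy in place of 2-hydroxyethyl on a saturated chain carbon bound to an amide-type nitrogen gives a number 6 percentage points lower from compound 3 to compound 4 (within the scatter), so these two chain ends are not separated here. With carboxymethyl in place of cyclopentyl on an amide-type nitrogen, the result is a number 20 percentage points lower from compound 2 to compound 4 (beyond the scatter), a second chain amide set apart from the cyclopentyl amide, after a number 14 percentage points lower from compound 2 to compound 3 (beyond the scatter). The core substituent can now be read on its own: hydrogen in place of methoxy on an aromatic carbon gives a number 15 percentage points lower from compound 1 to compound 4 (beyond the scatter), with the carboxymethyl amide held constant.

No measurement here bears on the reason for these steps. Open, going by these compounds, are whether an amine or a phenyl ring at the chain end would shift the number, and whether methoxy has the same effect on the core of compound 2 or compound 3.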